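The source may report more compounds than this note shows. Statements on the series, on what has been measured and on what is new or still open speak of the compounds shown alone.

Compound 1 `Clc1ccc2c(c1-c1ccn[nH]1)CCC2c1ncc[nH]1`: in a functional assay on CHO cells for agonist activity at Alpha-1B adrenergic receptor (Homo sapiens), read by FLIPR and calcium flux (a lower number here means that less compound is needed, a higher number that more compound is needed for the effect), compound 1 gives only a limit, > 10000 nM.
Compound 2 `Cn1cc(-c2cccc3c2CCC3c2ncc[nH]2)cn1`: in this assay compound 2 gives only a limit, > 10000 nM.
Compound 3 `Clc1ccc2c(c1-c1cn[nH]c1)CCC2c1ncc[nH]1`: in this assay compound 3 gives only a limit, > 10000 nM.

Compound 2 thus stands where every measured compound stands, at the limit, as the limit of > 10000 nM in this assay, at which 3 of the 3 values shown sit, shows. For the measured compounds named here, the single measured step, a step that the two limits leave unreadable from compound 1 to compound 3, runs between two limits and its size cannot be read. Compound 4 `CNC(=O)c1cccc2c1CCC2c1ncc[nH]1` differs from compound 2 as follows: methylcarbamoyl in place of 1-methyl-1H-pyrazol-4-yl on an aromatic carbon. Going by the values given here, no measured step bears on such a change, and the shared core has yielded no number anywhere. Compound 4 is therefore expected to remain near the limit, the step amounting to a step that the limit leaves unreadable from compound 2 to compound 4, with nothing beyond the scatter foreseen. The estimate for compound 4 is 15000 nM, ranging from 3000 nM to 60000 nM.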

Compound 4, half-maximal effective concentration: > 10000 nM
Compound 4 ended at the assay's limit (the forecaster's own chance of this, stated with the estimate: 80%); the middle value does not contradict the limit.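

Compound 2 and compound 4 both end at a limit in this assay, and no size can be read for the step between them. The compounds shown leave open whether any compound on the shared core gives a measurable value.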